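Removing a Chlorine From the Weakest Compound in the Series

The source may report more compounds than this note shows. Statements on the series, on what has been measured and on what is new or still open speak of the compounds shown alone.

Of the compounds shown here, three have been measured in a functional assay on HeLa cells (Homo sapiens) for cytotoxicity, read by MTT assay, with a stated time of 48 h; on this read-out higher numbers stand for weaker inhibition and lower numbers for stronger inhibition. Compound 1 `CCOC(=O)c1c(-c2c(Cl)c3ccccc3oc2=O)nn(-c2cccc(Cl)c2)c1C(=O)OCC` gives 40000 nM, compound 3 `CCOC(=O)c1c(-c2c(Cl)c3cc(C)ccc3oc2=O)nn(-c2cccc(Cl)c2)c1C(=O)OCC` gives 125000 nM, and compound 2 `CCOC(=O)c1c(-c2c(Cl)c3ccccc3oc2=O)nn(-c2ccc(Br)cc2)c1C(=O)OCC` gives 500000 nM, the highest of the three numbers, so compound 2 is the weakest inhibitor here. Compound 4 `CCOC(=O)c1c(-c2cc3ccccc3oc2=O)nn(-c2ccc(Br)cc2)c1C(=O)OCC` differs from compound 2 in one place: hydrogen in place of chloro on an aromatic carbon.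

Two measured steps exist for comparison. The step of a 13-fold higher number from compound 1 to compound 2 (1.10 log units; beyond the scatter) concerns the aryl group on the nitrogen, not the fused ring where the chlorine is removed. The step of a 3.1-fold higher number from compound 1 to compound 3 (0.49 log units; beyond the scatter) does touch the fused ring system, but it adds a methyl at another position rather than removing a chloro. Within the data shown here, no measured step changes this chlorine, so its contribution is unknown and no direction can be expected with confidence. For compound 4 the expected step is a 1.2-fold higher number from compound 2 to compound 4 (0.08 log units; within the scatter), little beyond the scatter. Compound 4 is therefore estimated at 600000 nM, within a range of 150000 nM to 2000000 nM.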

Compound 4, half-maximal inhibitory concentration: 250000 nM
For compound 4 the middle estimate is 2.4-fold (0.38 log units) above the measured one; the range from low to high includes it.
By their numbers in this assay, from the lowest: compound 1; then compounds 3, 4 and 2 (each within the scatter of the next, the first and the last beyond it).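

Hydrogen in place of chloro on the aromatic carbon opposite the ring oxygen gives a 2.0-fold lower number from compound 2 to compound 4 (0.30 log units; within the scatter), so this assay does not separate these two compounds. Among these compounds, this is the first measured step at this position, as the earlier steps changed the aryl group on the nitrogen or added a methyl elsewhere on the fused rings. With 4-bromophenyl on the nitrogen, the presence of the chlorine therefore makes no difference that can be read beyond the usual scatter, and no measurement here bears on why.

From the compounds shown here alone, the same swap remains open with 3-chlorophenyl on the nitrogen, as in compound 1, where the number is lower and a change might read differently. It is also unknown whether a different group at this position, such as an amine or a carboxylic acid, would move the number beyond the scatter.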